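The compounds below may be only part of what the source reports. "The series", "measured", "known", "first", "only" and "open" are said of these compounds alone.

Compound 1, with the structure `CC1(C)CC(NCCO)CC(C)(C)N1`, was examined in a physicochemical assay for lipophilicity (on this read-out higher numbers stand for higher lipophilicity and lower numbers for lower lipophilicity), where compound 1 gives 3.1. Compound 2, with the structure `C=CCN(CC=C)CCCN(CC=C)CC=C`, was examined alongside it; in this assay compound 2 gives 1.84. Of these two numbers, compound 1 has the higher one. The gap between compound 1 and compound 2 is larger than the scatter seen between repeated runs of this kind, and compound 1 stands as the more lipophilic of the pair.

From compound 1 a single change leads to compound 3, with the structure `CN(C)C1CC(C)(C)NC(C)(C)C1`: dimethylamino in place of (2-hydroxyethyl)amino on a saturated ring carbon. Going by the values given here, no pair of measured compounds differing in one place is available, so the size of this step cannot be read from measured data. It is expected to be an upward step in this assay, beyond the scatter, because compound 1 already sits at 3.1 and the change trades a group with two hydrogen-bond donors for one with none. The step from compound 1 to compound 3 is estimated at a number 0.80 log units higher from compound 1 to compound 3 (beyond the scatter). Compound 3 is expected to give about 3.9, within a range from 3.3 to 4.5.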

Compound 3, partition coefficient: 2.89
Beside the measured number, compound 3's estimate is 1.01 log units above it; the whole stated range lies above it.
By their numbers in this assay, from the lowest: compound 2; then compounds 3 and 1 (each within the scatter of the next).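

Replacing (2-hydroxyethyl)amino with dimethylamino on a saturated ring carbon, three ring bonds from the ring nitrogen, gives in this assay a step of a number 0.21 log units lower from compound 1 to compound 3 (within the scatter), so this change does not separate the two compounds on this read-out. Going by these compounds alone, this is the first pair of measured compounds that differ in one place, and it shows that at this position a group with 2 hydrogen-bond donors and 4 heavy atoms can give way to one with 0 donors and 3 heavy atoms without a difference beyond the scatter. No measurement at hand accounts for this result.

This single pair cannot show which part of the (2-hydroxyethyl)amino group matters, and a group that changes only one feature, such as (2-methoxyethyl)amino, or a longer chain such as (3-hydroxypropyl)amino, would be needed to address that. It also leaves open whether a primary amine or a carboxylic acid at this position would stay within the scatter of compound 1, and compound 2 differs from the others in more than one place, so its step cannot be read.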